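The source may report more compounds than this note shows. Statements on the series, on what has been measured and on what is new or still open speak of the compounds shown alone.

Measured so far:
compound 1, `Cc1ccc(Nc2[nH]c(C)nc3nccc2-3)cc1`, 759000000 nM
compound 2, `COc1ccc(Nc2[nH]c(C)nc3nccc2-3)cc1`, 661000000 nM

Both compounds were measured in a functional assay on the whole organism for inhibition, with Nicotiana tabacum as the target; a higher number here means a weaker inhibitor, a lower number a stronger inhibitor. Compound 2 holds the lowest of the two numbers in this assay, but its nearest neighbour is compound 1, and the step of a 1.1-fold lower number from compound 1 to compound 2 (0.06 log units; within the scatter) is within the scatter, so the two compounds cannot be placed in any order on these numbers.

The next compound in the series is compound 3, `CCOc1ccc(Nc2[nH]c(C)nc3nccc2-3)cc1`. It differs from compound 2 in one place: methyl in place of hydrogen on a saturated chain carbon bound to an oxygen on an aromatic ring. Cut one bond further out, this reads methyl to ethyl, or methoxy to ethoxy.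

Going by the values given here, only one measured step bears on this change, and only loosely: the step of a 1.1-fold lower number from compound 1 to compound 2 (0.06 log units; within the scatter), which exchanged methyl for methoxy on the aromatic carbon and moved the number by no more than the scatter. Among the compounds with values here, no step that lengthens a chain on the oxygen has been measured. On that basis no shift beyond the scatter is expected in this assay, and the step of a 1.1-fold lower number from compound 2 to compound 3 (0.03 log units; within the scatter) is the estimate. Compound 3 is expected to give about 620000000 nM, with a range from 250000000 nM to 1500000000 nM.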

Compound 3, half-maximal inhibitory concentration: 347000000 nM
Compound 3: middle estimate off by 1.8-fold (0.25 log units), on the high side; the range from low to high includes it.
By their numbers in this assay, from the lowest: compounds 3, 2 and 1 (each within the scatter of the next, the first and the last beyond it).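

In this assay, methyl in place of hydrogen on the saturated chain carbon bound to an oxygen on an aromatic ring, read as methoxy to ethoxy, gives a 1.9-fold lower number from compound 2 to compound 3 (0.28 log units; within the scatter) and so does not separate the two compounds. Read against the methyl of compound 1, the ethoxy group gives a 2.2-fold lower number from compound 1 to compound 3 (0.34 log units; beyond the scatter) and is the first step in the series printed beyond the scatter, though only a modest one, while compound 2 remains within the scatter of both neighbours. Nothing at hand bears on the reason for this step.

From the compounds shown here alone, it remains open whether a longer chain on the oxygen, such as propoxy or butoxy, would move the number any further from that of compound 1, and how an amine or a carboxylic acid would read in place of the ethoxy group on the aromatic carbon. The compounds shown also differ only in this one group, so they say nothing about changes elsewhere on the shared core.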